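This account rests on a few compounds, and the source may have more. Where it says the series, first, only, none or still open, it means among the compounds named here.

Compound 1 `Oc1cccc(-c2ccc3ccccc3c2)c1` — 12%
Compound 2 `Oc1cccc2cc(-c3ccc(F)cc3)ccc12` — < 10%

Both measured compounds were examined in an assay for binding affinity to 17-beta-hydroxysteroid dehydrogenase type 2 (Homo sapiens), with a stated time of 20 min, tested at 1 uM; a lower number here means less inhibition, a higher number more inhibition at the concentration tested (going by the name of the read-out). Compound 1 gives 12%. Compound 2 gives < 10%, which is a limit of the assay rather than a number. Compound 2 therefore sits at the limit of < 10% in this assay, at which 1 of the 2 values shown sits, so its standing on this assay is known only as a bound. Among the measured compounds shown here, no step between measured compounds is available here, and the two values show only that neither compound inhibits strongly at the concentration tested.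

Compound 3 `CNS(=O)(=O)c1ccc(-c2ccc3c(O)cccc3c2)cc1` is the next compound to be measured. It differs from compound 2 by methylsulfamoyl in place of fluoro on an aromatic carbon. For the measured compounds named here, with no measured step to guide the size of this change, compound 3 is expected to show a number at least 10 percentage points higher from compound 2 to compound 3 (that floor lies within the scatter), a rise that may not exceed the usual scatter. The estimate for compound 3 is 20%, with a range from 0% to 45%.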

Compound 3, a percentage reported as inhibition, at one concentration (the size of the read-out at that concentration, not a potency): 57%
Compound 3: middle estimate off by 37 percentage points, on the low side; the whole stated range lies below it.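

Putting methylsulfamoyl in place of fluoro, on the aromatic carbon para to a large group, gives in this assay a number at least 47 percentage points higher from compound 2 to compound 3 (beyond the scatter), the only measured step shown so far. The earlier compounds shown here showed only that neither inhibits strongly at the concentration tested, whereas this change shows that the read-out at this position depends strongly on the group it carries. Compound 2 stands at a limit of the assay and not at a number, so the step is known only as a floor: the limit of < 10% in this assay, at which 1 of the 3 values shown sits.

The compounds shown leave open which part of methylsulfamoyl goes with this rise, as the group entered whole in a single change. A methylsulfonyl, an unsubstituted sulfamoyl or a carboxylic acid on the same carbon would separate these parts.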